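Octyl-triazole chalcone series: benzyl replacement at the triazole

This account rests on a few compounds, and the source may have more. Where it says the series, first, only, none or still open, it means among the compounds named here.

Measured so far in a functional assay on MCF7 cells (Homo sapiens) for inhibition, read by MTT assay; a lower number here means a stronger inhibitor, a higher number a weaker inhibitor:
compound 1 `CCCCCCCCn1cc(/C=C/C(=O)c2ccc(NC(=O)CN3CCN(c4ccccc4F)CC3)cc2)nn1`: 68600 nM
compound 2 `CCCCCCCCCCn1cc(/C=C/C(=O)c2ccc(NC(=O)CN3CCN(c4ccccc4)CC3)cc2)nn1`: > 100000 nM, a limit of this assay, not a number
compound 3 `CCCCCCCCn1cc(/C=C/C(=O)c2ccc(NC(=O)CN3CCN(C(=O)OC(C)(C)C)CC3)cc2)nn1`: 98400 nM

All three compounds sit at the weak end of this assay. Compound 2 stands at the limit of > 100000 nM in this assay, at which 1 of the 3 values shown sits, so its value is a limit only and no number is known for it. Within the data shown here, the single step within the set, a 1.4-fold higher number from compound 1 to compound 3 (0.16 log units; within the scatter), changes the group on the amine nitrogen in the ring and does not touch the chain on the triazole nitrogen.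

Compound 4 `O=C(CN1CCN(c2ccccc2)CC1)Nc1ccc(C(=O)/C=C/c2cn(Cc3ccc(Br)cc3)nn2)cc1` is not yet measured. It differs from compound 2 at the triazole end: 4-bromophenyl in place of nonyl on a saturated chain carbon bound to an aromatic nitrogen. Among the measured compounds shown here, no measured step bears on this position, so nothing in the set gives a direction for the change. Because compound 2 itself sits at the limit of > 100000 nM in this assay, at which 1 of the 3 values shown sits, the baseline for the step is uncertain as well. The expected step is therefore an at least 1.2-fold lower number from compound 2 to compound 4 (0.09 log units; that floor lies within the scatter), read against a limit and with no evidence for a change beyond the scatter. For compound 4 the estimate in this assay is 80000 nM, with a range from 25000 nM to 250000 nM, and a fair chance that only a limit is reported again.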

Compound 4, half-maximal inhibitory concentration: 49200 nM
The estimate for compound 4 lay 1.6-fold (0.21 log units) above the measured number; the measured number falls inside the stated range.
By their numbers in this assay, from the lowest: compounds 4, 1 and 3 (each within the scatter of the next). At a limit, above all of these: compound 2.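

In this assay, 4-bromophenyl in place of nonyl on a saturated chain carbon bound to an aromatic nitrogen gives an at least 2.0-fold lower number from compound 2 to compound 4 (0.30 log units; that floor lies within the scatter). Among these compounds, this is the first step in the set at this position, and it replaces a limit with a measured number, so a chain ending in an aromatic ring, read as decyl to 4-bromobenzyl, still gives a value in this assay, though one at the weak end. The true size of the step stays unknown and only its floor is printed, as the value of compound 2 is a limit and not a number: the limit of > 100000 nM in this assay, at which 1 of the 4 values shown sits.

Going by these compounds, whether the step truly exceeds the scatter stays open, and so does how much of it belongs to the aromatic ring and how much to the bromine. An unsubstituted benzyl, a shorter chain such as butyl, or a benzyl carrying an amine or a carboxylic acid at this position would separate those contributions and show whether this position can move the series away from the weak end of this assay.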